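The source may hold more compounds than are shown below. What is called first, only, known or untested is meant among the compounds shown, and "the series" means these compounds.

Measured compounds:
compound 1, `COc1ccc2nc(N(Cc3cc(-c4ccc(OC(F)(F)F)cc4)no3)c3nc4ccc(F)cc4s3)sc2c1`, 9940 nM
compound 2, `COc1ccc(-c2cc(CN(c3nc4ccc(F)cc4s3)c3nc4ccc(OC)cc4s3)on2)cc1`, 11400 nM
compound 3, `COc1ccc2nc(N(Cc3cc(-c4cc(OC)c(OC)c(OC)c4)no3)c3nc4ccc(F)cc4s3)sc2c1`, 11800 nM

In a functional assay on COLO 205 cells (Homo sapiens) for antiproliferative activity, read by MTT assay (on this read-out higher numbers stand for weaker inhibition and lower numbers for stronger inhibition), compound 3 gives 11800 nM, the largest number of the three, yet the gaps to it do not reach beyond the scatter: a 1.0-fold higher number from compound 2 to compound 3 (0.01 log units; within the scatter) and a 1.2-fold higher number from compound 1 to compound 3 (0.07 log units; within the scatter). Compound 4, `COc1ccc2nc(N(Cc3cc(-c4ccccc4F)no3)c3nc4ccc(F)cc4s3)sc2c1`, has not been measured. It differs from compound 3 in one place: 2-fluorophenyl in place of 3,4,5-trimethoxyphenyl on an aromatic carbon. For the measured compounds named here, the steps that bear on this change are the earlier exchanges of the aryl group on the same carbon of the five-membered ring, namely a 1.2-fold higher number from compound 1 to compound 3 (0.07 log units; within the scatter), a 1.0-fold higher number from compound 2 to compound 3 (0.01 log units; within the scatter) and a 1.1-fold higher number from compound 1 to compound 2 (0.06 log units; within the scatter), every one of them within the scatter. Three different aryl groups at that position therefore gave numbers that cannot be told apart in this assay. Compound 4 is accordingly expected to give no step beyond the scatter, a 1.1-fold lower number from compound 3 to compound 4 (0.03 log units; within the scatter). For compound 4 the value in this assay is estimated at 11000 nM, with a range from 4500 nM to 28000 nM.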

Compound 4, half-maximal inhibitory concentration: 13400 nM
Beside the measured number, compound 4's estimate is 1.2-fold (0.09 log units) below it; measured number inside the range.
By their numbers in this assay, from the lowest: compounds 1, 2, 3 and 4 (each within the scatter of the next).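

In this assay the change to 2-fluorophenyl stays within the scatter against each earlier aryl group: a 1.1-fold higher number from compound 3 to compound 4 (0.06 log units; within the scatter), a 1.2-fold higher number from compound 2 to compound 4 (0.07 log units; within the scatter) and a 1.3-fold higher number from compound 1 to compound 4 (0.13 log units; within the scatter). All the earlier aryl groups carried oxygen, whereas 2-fluorophenyl has none, with 0 hydrogen-bond acceptors against 3 and fewer heavy atoms than the 3,4,5-trimethoxyphenyl it replaces, so this position tolerates a wider change than the earlier compounds had shown, with no measurable shift in the number. Nothing available accounts for this lack of response.

All four compounds keep a substituted phenyl ring on this carbon of the five-membered ring. From the compounds shown here alone, whether an amine, a carboxylic acid or a longer alkyl chain there would produce a step beyond the scatter remains open.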